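An isopropoxy group added to compound 2

The compounds below may be only part of what the source reports. "The series", "measured", "known", "first", "only" and "open" are said of these compounds alone.

Values in an ADME assay on DU-145 cells (Homo sapiens) for cytotoxicity, read by MTT assay, with a stated time of 72 h; on this read-out higher numbers stand for weaker inhibition and lower numbers for stronger inhibition:
- Compound 1 `COc1ccc(C2=C(c3cc(OC)c(OC)c(OC)c3)C(=O)C(OC(C)=O)C2)cc1OC(C)C`: > 100 ug/mL
- Compound 2 `COc1ccc(C2=C(c3cc(OC)c(OC)c(OC)c3)C(=O)C(O[SiH2]C(C)(C)C)C2)cc1`: 28 ug/mL

Within the data shown here, only two compounds have been measured so far, and compound 2 holds the only true number, at 28 ug/mL. Compound 1 reads > 100 ug/mL, which is a limit of this assay and not a number. With so little data, compound 2 cannot be ranked on any real scale.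

The next compound, compound 3 `COc1ccc(C2=C(c3cc(OC)c(OC)c(OC)c3)C(=O)C(O[SiH2]C(C)(C)C)C2)cc1OC(C)C`, keeps compound 2 intact except for one change: isopropoxy in place of hydrogen on an aromatic carbon. In words, isopropoxy takes the place of hydrogen on an aromatic carbon, turning 4-methoxyphenyl into 3-isopropoxy-4-methoxyphenyl.

Among the measured compounds shown here, no measured pair shows this change on its own. The only hint is weak: compound 1, which also carries 3-isopropoxy-4-methoxyphenyl, gives > 100 ug/mL, again a limit. A small move towards weaker inhibition is therefore expected, possibly no larger than the usual scatter. The expected change is a 1.6-fold higher number from compound 2 to compound 3 (0.21 log units; within the scatter). Compound 3 is estimated at 45 ug/mL, with an expected range from 15 ug/mL to 100 ug/mL.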

Compound 3, half-maximal inhibitory concentration: 6.3 ug/mL
The estimate for compound 3 lay 7.1-fold (0.85 log units) above the measured number; the measured number lies below the stated range.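

In this assay, isopropoxy in place of hydrogen on this aromatic carbon, ortho to a methoxy group, gives a 4.4-fold lower number from compound 2 to compound 3 (0.65 log units; beyond the scatter), so here the added group goes with stronger inhibition, not weaker. Compound 1 and compound 3 share the 3-isopropoxy-4-methoxyphenyl group and differ only in the group on the oxygen on a saturated carbon, and that single change gives an at least 15-fold lower number from compound 1 to compound 3 (1.20 log units; beyond the scatter), so the isopropoxy group alone does not bring weak inhibition, and the group on that oxygen also matters. Compound 1 stands at a limit of the assay and not at a true number: the limit of > 100 ug/mL in this assay, at which 1 of the 3 values shown sits.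

The compounds shown leave open how an ethoxy, a hydroxy or an amine on this aromatic carbon would compare with isopropoxy. They also leave open whether the isopropoxy step would hold if a free hydroxyl sat on the saturated carbon in place of the silicon-bearing group.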